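Trimming a Side Chain: Sec-Butyl to Isopropyl

The source may report more compounds than this note shows. Statements on the series, on what has been measured and on what is new or still open speak of the compounds shown alone.

Of the compounds shown here, two have so far been measured in a functional assay on HeLa cells (Homo sapiens) for antiproliferative activity, read by CCK-8 assay, with a stated time of 72 h; on this read-out lower numbers stand for stronger inhibition and higher numbers for weaker inhibition. Compound 1, `CCC(C)n1cnc2c(NCc3ccc(C(=O)Nc4ccccc4N)cc3)nc(Cl)nc21`, gives 3030 nM in this assay, the lower of the two numbers. Among the compounds with values here, compound 2, `Nc1ccccc1NC(=O)c1ccc(Cn2cnc3c(NCc4ccccc4)nc(Cl)nc32)cc1`, gives 6770 nM in this assay, a number that lies beyond the usual scatter from that of compound 1; no single-point step between these two is set out, so only the two values themselves can be compared, and they differ in more than one place.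

Compound 3, `CC(C)n1cnc2c(NCc3ccc(C(=O)Nc4ccccc4N)cc3)nc(Cl)nc21`, has not yet been measured. It differs from compound 1 in one place: hydrogen in place of methyl on a saturated chain carbon, two bonds along the chain from an aromatic nitrogen. Cut one bond further out, the same difference reads as ethyl to methyl, or sec-butyl to isopropyl.

Within the data shown here, no step between measured compounds bears on this change, so the expectation rests on compound 1 alone. The change is confined to the saturated chain, the rest of compound 1 staying as it is, and the expected step of a 1.3-fold higher number from compound 1 to compound 3 (0.10 log units; within the scatter) is small, not beyond the scatter in either direction. Compound 3 is therefore estimated at 3800 nM, with a range from 1500 nM to 10000 nM.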

Compound 3, half-maximal inhibitory concentration: 2130 nM
For compound 3 the middle estimate is 1.8-fold (0.25 log units) above the measured one, and the stated range covers the measured number.
By their numbers in this assay, from the lowest: compounds 3 and 1 (each within the scatter of the next); then compound 2.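

Within the data shown here, this is the first step that changes one place alone, and it gives a direct reading of the saturated chain on the aromatic nitrogen: in this assay, the change from sec-butyl to isopropyl gives a 1.4-fold lower number from compound 1 to compound 3 (0.15 log units; within the scatter). Removing that methyl, with the rest of compound 1 left as it is, therefore produces no difference that can be told apart from the scatter of repeated measurements, so this one carbon of the chain carries no detectable weight in this read-out. Nothing measured here accounts for how closely the two compounds agree.

From the compounds shown here alone, the two compounds cover only sec-butyl and isopropyl at this position, so the step says nothing about how far the same result extends, and whether a methyl, a longer chain such as n-hexyl, a cyclopentyl ring or a chain bearing a hydroxyl or an amine would read the same remains open. Compound 2 also remains apart from this comparison, as it differs from compound 1 and compound 3 in more than one place, which leaves the contribution of each of those differences unresolved.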